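Aryl amine exchange on a shared core, cytotoxicity

A few compounds are considered here, and "the series" means these few. Any claim that something is new, unique, unknown or untested is made for them only; others in the source may bear on it.

Three compounds of the series keep one core and differ only in the aryl group on the nitrogen on an aromatic ring. Compound 1 `COc1ccccc1Nc1nc(-c2cccc(F)c2)nc2ccc(F)cc12` carries a 2-methoxyphenyl there, compound 2 `Fc1cccc(-c2nc(Nc3ccccc3F)c3cc(F)ccc3n2)c1` a 2-fluorophenyl and compound 3 `Oc1ccc(Nc2nc(-c3cccc(F)c3)nc3ccc(F)cc23)cc1` a 4-hydroxyphenyl. In a functional assay on U2OS cells (Homo sapiens) for cytotoxicity, read by MTT assay, with a stated time of 48 h (a lower number here means a stronger inhibitor, a higher number a weaker inhibitor), compound 1 gives > 50000 nM, which is a limit of the assay and not a number. Compound 2 likewise gives > 50000 nM, a limit. Compound 3 gives > 50000 nM, again a limit. Going by the values given here, every value measured so far is the limit of > 50000 nM in this assay, at which 3 of the 3 values shown sit, so the steps a step that the two limits leave unreadable from compound 1 to compound 2, a step that the two limits leave unreadable from compound 1 to compound 3 and a step that the two limits leave unreadable from compound 2 to compound 3 cannot be read in size or direction.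

Compound 4 `Nc1cccc(Nc2nc(-c3cccc(F)c3)nc3ccc(F)cc23)c1` is the next variant on the same nitrogen: 3-aminophenyl in place of 2-methoxyphenyl on a nitrogen on an aromatic ring. Among the compounds with values here, the steps that bear on this change are those that also exchange the aryl on the nitrogen, a step that the two limits leave unreadable from compound 1 to compound 3 and a step that the two limits leave unreadable from compound 2 to compound 3, and both are unreadable, so no direction can be taken from them. What remains is that every measured analogue sits at the limit. Compound 4 is therefore expected to stay at the limit too, an expected step of a number no higher from compound 1 to compound 4 (the limit leaves the size open). The estimate for compound 4 is 50000 nM, with an expected range from 20000 nM to 100000 nM, and the assay will most probably again report only a limit.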

Compound 4, half-maximal inhibitory concentration: 49700 nM
Compound 4: middle estimate off by 1.0-fold (0.00 log units), on the high side, within the range that was stated.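

Going by these compounds alone, with 3-aminophenyl on the nitrogen, compound 4 gives 49700 nM in this assay, the only value shown that is a number and not a limit, so an aryl exchange at this position can give a readable result, though only just. The exchange reads as a number no higher from compound 1 to compound 4 (the limit leaves the size open), as a number no higher from compound 3 to compound 4 (the limit leaves the size open) and as a number no higher from compound 2 to compound 4 (the limit leaves the size open), which fixes a direction for each pair and leaves every size unread. The rest of the series remains at the limit, and the readable window at this position is still only a single point: the limit of > 50000 nM in this assay, at which 3 of the 4 values shown sit.

As far as these compounds go, whether any aryl on this nitrogen can move the series well away from the limit stays open, as does whether the amino group of compound 4 matters at all, with one number sitting at the edge of the range and no slope to read. A dimethylamino group, a carboxylic acid or a longer aminoalkyl chain in place of the amino group of the 3-aminophenyl would test this on the same shared core.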